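One Chloro Removed: Expecting the Growth Inhibition of Compound 4

The source may report more compounds than this note shows. Statements on the series, on what has been measured and on what is new or still open speak of the compounds shown alone.

Compound 3 `ClCc1ccccc1Cn1cnc2nc(Cl)nc(Cl)c21` gives 400 nM in a functional assay on HT-29 cells (Homo sapiens) for cytotoxicity, read by sulforhodamine B assay, with a stated time of 48 h; a higher number here means a weaker inhibitor of growth, a lower number a stronger inhibitor of growth. Compound 2 `ClCc1ccccc1Cn1cnc2ncnc(Cl)c21` differs from it only by hydrogen in place of chloro on an aromatic carbon, and in this assay compound 2 gives 3890 nM, a step of a 9.7-fold higher number from compound 3 to compound 2 (0.99 log units; beyond the scatter). Compound 1 `ClCc1ccc(Cn2cnc3nc(Cl)nc(Cl)c32)cc1` has the same atoms as compound 3 joined differently; the difference between the two cores is not broken down here. In this assay compound 1 gives 3540 nM, which lies within the scatter of compound 2. Compound 4 `ClCc1ccc(Cn2cnc3ncnc(Cl)c32)cc1` has not yet been measured. Going by the values given here, it differs from compound 1 by hydrogen in place of chloro on an aromatic carbon, the same change, at the same surroundings, as the one from compound 3 to compound 2. Compound 4 is therefore expected to show a step of a 5.6-fold higher number from compound 1 to compound 4 (0.75 log units; beyond the scatter), resting on the earlier step of a 9.7-fold higher number from compound 3 to compound 2 (0.99 log units; beyond the scatter), but taken somewhat smaller because compound 1 already gives 3540 nM. Compound 4 is expected to give about 20000 nM, likely between 5000 nM and 70000 nM.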

Compound 4, concentration for 50% growth inhibition: 1230 nM
Beside the measured number, compound 4's estimate is 16-fold (1.21 log units) above it; measured number below the stated range.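

In this assay, hydrogen in place of the chloro between two ring nitrogen atoms gives a 2.9-fold lower number from compound 1 to compound 4 (0.46 log units; beyond the scatter), so on the core of compound 1 the change goes with stronger growth inhibition. On the core of compound 3, the same change goes with weaker growth inhibition, so its effect did not carry from one core to the other: the same change on two cores in this assay, a 9.7-fold higher number (0.99 log units; beyond the scatter) from compound 3 to compound 2 and a 2.9-fold lower number (0.46 log units; beyond the scatter) from compound 1 to compound 4, 28-fold (1.45 log units) apart, beyond the scatter of two such steps. These two pairs show that the core matters here, but they do not show why, or what the change would do on any further core.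

The compounds shown leave open what other groups would do at this ring carbon. An amine or a methoxy group in place of the chloro, on either core, would be one such test.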